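Methoxy in place of chloro on the shared core

This account rests on a few compounds, and the source may have more. Where it says the series, first, only, none or still open, it means among the compounds named here.

Compound 3 `CS(=O)(=O)c1ccc(Nc2nccc(Nc3nc4ccc(Cl)cc4s3)n2)cc1` is tested in a functional assay on PC-3 cells (Homo sapiens) for antiproliferative activity, read by MTT assay, with a stated time of 48 h; on this read-out lower numbers stand for stronger inhibition and higher numbers for weaker inhibition. In this assay compound 3 returns only a limit, > 50000 nM. Compound 2 `Cc1ccc2nc(Nc3ccnc(Nc4ccc(S(C)(=O)=O)cc4)n3)sc2c1` likewise returns only a limit, > 50000 nM. The step that the two limits leave unreadable from compound 2 to compound 3 therefore has no readable size, both values sitting at the limit of > 50000 nM in this assay, at which 2 of the 3 values shown sit. Compound 1 `COc1ccc2nc(Nc3nc(Nc4ccc(S(C)(=O)=O)cc4)ncc3F)sc2c1`, which carries a fluorine that the other two lack, gives 1270 nM in this assay.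

Compound 4 `COc1ccc2nc(Nc3ccnc(Nc4ccc(S(C)(=O)=O)cc4)n3)sc2c1` is compound 3 with methoxy in place of chloro on an aromatic carbon. Within the data shown here, no measured step covers methoxy in place of chloro directly. The two measured compounds without the fluorine, compound 2 and compound 3, both stop at the limit, so on this scaffold no change of the group at that position has yet produced a readable number. Among the measured compounds shown here, compound 1 shows methoxy alongside a readable number, but it differs from compound 4 in the fluorine as well, and no step between compound 1 and compound 4 is measured. Compound 4 is therefore expected to be weak, with a real chance of another limit, and the estimate is 30000 nM with a range from 5000 nM to 100000 nM. The step this estimate implies is an at least 1.6-fold lower number from compound 3 to compound 4 (0.22 log units; that floor lies within the scatter), expected to stay unreadable.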

Compound 4, half-maximal inhibitory concentration: 2700 nM
The estimate for compound 4 lay 11-fold (1.05 log units) above the measured number, and the stated range ends above it.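

With the fluorine absent from the shared core, the group at this position decides whether this assay gives a readable number: methoxy in place of chloro brings an at least 18-fold lower number from compound 3 to compound 4 (1.26 log units; beyond the scatter), and methoxy in place of methyl brings an at least 18-fold lower number from compound 2 to compound 4 (1.26 log units; beyond the scatter). Both sizes are floors, since each starting value is a limit and not a number: the limit of > 50000 nM in this assay, at which 2 of the 4 values shown sit. Hydrogen in place of fluoro is a modest change by comparison, with a 2.1-fold higher number from compound 1 to compound 4 (0.33 log units; beyond the scatter), so among these compounds the readable activity goes with methoxy and does not depend on the fluorine.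

Only methyl, chloro and methoxy are shown at this position, so it remains open whether ethoxy, hydroxyl or an amine there would keep a readable number. Also open, on these data alone, is whether the fluoro step would keep its size with any group other than methoxy at this position.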